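The source may hold more compounds than are shown below. What is called first, only, known or untested is meant among the compounds shown, and "the series" means these compounds.

Measured compounds:
compound 1 `CCc1cc(C(C)=O)c(O)cc1OCCCC(C)(C)C(=O)O`: 43%
compound 2 `CCc1cc(C(C)=O)c(O)cc1OCCCCCC(C)(C)c1nnnn1C`: 59%
compound 3 `CCc1cc(C(C)=O)c(O)cc1OCCCCCCSC`: 14%

In an assay on isolated protein for binding affinity to leukotriene B4 receptor 1 (Homo sapiens), tested at 1 uM (a higher number here means more inhibition at the concentration tested (going by the name of the read-out), a lower number less inhibition), compound 3 stands lowest of the three numbers shown, and both gaps to it lie beyond the scatter: a number 29 percentage points lower from compound 1 to compound 3 (beyond the scatter), and a number 45 percentage points lower from compound 2 to compound 3 (beyond the scatter). Both of these steps end at compound 3 and both exchange a chain-end group with several hetero atoms, the 1-carboxy-1-methylethyl of compound 1 or the 1-methyl-1-(1-methyl-1H-tetrazol-5-yl)ethyl of compound 2, for the (methylsulfanyl) group of compound 3, and both lower the number.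

Compound 4 `CCc1cc(C(C)=O)c(O)cc1OCCCCCn1cncn1` is the next point on the chain end. 1H-1,2,4-triazol-1-yl in place of (methylsulfanyl)methyl on a saturated chain carbon, five bonds along the chain from an oxygen on an aromatic ring

The two steps into compound 3 bear on this change only in reverse: a chain end with more hetero atoms in place of (methylsulfanyl)methyl has so far gone with a higher number, once modestly and once largely. The entering 1H-1,2,4-triazol-1-yl is neither the carboxy group of compound 1 nor the tetrazolyl of compound 2, so the full size of either step cannot be assumed. A rise beyond the scatter, of modest size, is expected: a number 18 percentage points higher from compound 3 to compound 4 (beyond the scatter). Compound 4 is therefore estimated at 32%, with a range from 12% to 55%.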

Compound 4, a percentage reported as inhibition, at one concentration (the size of the read-out at that concentration, not a potency): 30%
Compound 4: the middle estimate sits 2 percentage points above what was measured; the range from low to high includes it.
By their numbers in this assay, from the lowest: compound 3; then compound 4; then compound 1; then compound 2.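

In this assay, the 1H-1,2,4-triazol-1-yl chain end places compound 4 in the middle of the set: there is a number 16 percentage points higher from compound 3 to compound 4 (beyond the scatter), but also a number 29 percentage points lower from compound 2 to compound 4 (beyond the scatter) and a number 13 percentage points lower from compound 1 to compound 4 (beyond the scatter). A five-membered aromatic ring with hetero atoms at the chain end therefore does not by itself set the number, as compound 2 and compound 4 both carry such a ring yet differ beyond the scatter, and that step changes the ring and the branched carbon together. Nothing beyond these numbers bears on why the steps have these sizes.

Going by these compounds, it stays open whether the gap between compound 2 and compound 4 follows the ring or the branching; a 1H-1,2,4-triazol-1-yl on the same 1-methylethyl branch, or a 1-methyl-1H-tetrazol-5-yl directly on the saturated chain carbon, would separate the two. Also open, on these data alone, is how a carboxylic acid or a primary amine at the chain end of compound 4, or a longer chain carrying the 1H-1,2,4-triazol-1-yl, would stand.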